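The source may report more compounds than this note shows. Statements on the series, on what has been measured and on what is new or still open speak of the compounds shown alone.

Compound 1 `CC(C)CCc1ccc2c(NCCCNCc3ccco3)ccnc2c1` gives 9.47.
Compound 2 `Fc1ccc(Oc2ccc3c(NCCCNCc4ccco4)ccnc3c2)cc1` gives 9.28.
Compound 3 `COc1cccc(Oc2ccc3c(NCCCNCc4ccco4)ccnc3c2)c1` gives 9.28.

In a physicochemical assay for acid dissociation, compound 1 holds the highest of the three numbers, but its steps to the others, a number 0.19 log units lower from compound 1 to compound 2 (within the scatter) and a number 0.19 log units lower from compound 1 to compound 3 (within the scatter), lie within the scatter, so no order can be read among them. Compound 4 `FC(F)(F)c1cccc(Cc2ccc3c(NCCCNCc4ccco4)ccnc3c2)c1` differs from compound 1 in one place: 3-(trifluoromethyl)phenyl in place of isobutyl on a saturated chain carbon bound to an aromatic carbon. Among the measured compounds shown here, the steps that bear on this are the two from compound 1, where 4-fluorophenoxy or 3-methoxyphenoxy replaced isopentyl on an aromatic carbon; both were within the scatter, as was no change at the digits printed from compound 2 to compound 3 (within the scatter). For the measured compounds named here, no measured step exchanges a group on a saturated chain carbon, so the expectation rests only on the steadiness of the numbers. Compound 4 is expected to show a number 0.17 log units lower from compound 1 to compound 4 (within the scatter), not beyond the scatter. The value of compound 4 in this assay is estimated at 9.3, between 8.95 and 9.65.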

Compound 4, acid dissociation constant: 9.47
Compound 4: middle estimate off by 0.17 log units, on the low side; measured number inside the range.
By their numbers in this assay, from the lowest: compounds 2, 3, 1 and 4 (each within the scatter of the next).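

In this assay, 3-(trifluoromethyl)phenyl in place of isobutyl on a saturated chain carbon bound to an aromatic carbon gives no change at the digits printed from compound 1 to compound 4 (within the scatter). The earlier steps shown here exchanged groups only on an aromatic carbon or on an oxygen on an aromatic ring, whereas this one shows that a group with a six-membered aromatic ring can enter at a saturated chain carbon without a step beyond the scatter. Nothing measured here speaks to the reason for this. Going by these compounds, what an amine or a carboxylic acid at this place would give in this assay stays open.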